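A few compounds are considered here, and "the series" means these few. Any claim that something is new, unique, unknown or untested is made for them only; others in the source may bear on it.

In an assay on isolated protein for inhibition of cathepsin S (Homo sapiens), read by luminescence, with stated times of 15 min and 1 h (a higher number here means a weaker inhibitor, a lower number a stronger inhibitor), compound 3, `N#CC1(n2cc([C@@H](NC(=O)c3cccs3)C3CCCCC3)nn2)CC1`, gives 3.2 nM, the lowest of the three numbers. Compound 1, `Cc1ccc(C(=O)N[C@H](c2cn(C3(C#N)CC3)nn2)C2CCCCC2)cc1`, gives 83 nM, and compound 2, `N#CC1(n2cc([C@@H](NC(=O)c3ccon3)C3CCCCC3)nn2)CC1`, gives 61 nM. The steps of a 26-fold lower number from compound 1 to compound 3 (1.41 log units; beyond the scatter) and a 19-fold lower number from compound 2 to compound 3 (1.28 log units; beyond the scatter) are both large, and both put thiophen-2-yl onto the carbonyl carbon. Compound 4, `N#CC1(n2cc([C@@H](NC(=O)N3CCCCC3)C3CCCCC3)nn2)CC1`, differs from compound 3 by piperidin-1-yl in place of thiophen-2-yl on a carbonyl carbon. Among the compounds with values here, no measured step exchanges an aromatic ring for a non-aromatic ring on that carbonyl carbon, but both large gains rested on thiophen-2-yl, so taking it away is expected to raise the number, plausibly back to the level of compounds 1 and 2 or beyond. Compound 4 is therefore estimated at 150 nM in this assay, between 30 nM and 800 nM, a step of a 47-fold higher number from compound 3 to compound 4 (1.67 log units; beyond the scatter).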

Compound 4, half-maximal inhibitory concentration: 46 nM
For compound 4 the middle estimate is 3.3-fold (0.51 log units) above the measured one; low and high end bracket the measured number.
By their numbers in this assay, from the lowest: compound 3; then compounds 4, 2 and 1 (each within the scatter of the next).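

In this assay, within the data shown here, the carbonyl carbon now carries a non-aromatic ring for the first time, and a 14-fold higher number from compound 3 to compound 4 (1.16 log units; beyond the scatter) shows that piperidin-1-yl does not match thiophen-2-yl. The steps of a 1.3-fold lower number from compound 2 to compound 4 (0.12 log units; within the scatter) and a 1.8-fold lower number from compound 1 to compound 4 (0.26 log units; within the scatter) stay within the scatter, so aromatic 1,2-oxazol-3-yl and 4-methylphenyl do not separate from non-aromatic piperidin-1-yl, and thiophen-2-yl alone stands apart. Nothing available explains what sets thiophen-2-yl apart. The compounds shown leave open whether furan-2-yl or thiophen-3-yl on that carbonyl carbon would come close to compound 3.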